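A few compounds are considered here, and "the series" means these few. Any claim that something is new, unique, unknown or untested is made for them only; others in the source may bear on it.

The compounds in this set share one core, with an amide whose nitrogen carries a variable group and an aromatic ring that is varied as well. Compound 1, `C=CC1=C(C(=O)NCc2ccc(C)cc2)C(c2ccc(F)cc2)OC1`, was tested in a functional assay on SW480 cells (Homo sapiens) for cytotoxicity, read by MTT assay, with a stated time of 24 h; a lower number here means a stronger inhibitor, a higher number a weaker inhibitor. In this assay compound 1 gives > 100000 nM, which is a limit of the assay rather than a number. Compound 2, `C=CC1=C(C(=O)NC(C)(C)C)C(c2ccc(OC)cc2)OC1`, also gives only a limit in this assay, > 100000 nM. Going by the values given here, compound 3, `C=CC1=C(C(=O)NC2CCCCC2)C(c2ccc(OC)c(OC)c2)OC1`, is the single compound with a measured number, giving 19100 nM in this assay. Compound 1 thus stands at the limit of > 100000 nM in this assay, at which 2 of the 3 values shown sit, and no measured number is available for it. Compound 4, `C=CC1=C(C(=O)Nc2ccccc2)C(c2ccc(F)cc2)OC1`, has not yet been measured. It differs from compound 1 by phenyl in place of 4-methylbenzyl on an amide-type nitrogen. Among the compounds with values here, no step between two measured compounds is available to guide how large this change might be; the expectation for compound 4 is a step within the scatter, and a number no higher from compound 1 to compound 4 (the limit leaves the size open) is the step estimated. Compound 4 is expected to give 100000 nM in this assay, within a range from 30000 nM to 300000 nM, most likely again reported only as a limit.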

Compound 4, half-maximal inhibitory concentration: > 100000 nM
Compound 4: no number, only a limit (the forecaster's own chance of this, stated with the estimate: 65%); the middle value lies on the limit itself.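

In this assay, going by these compounds alone, compound 4 gives > 100000 nM, a limit rather than a number; compound 1 also gives only a limit, so no step between the two can be read. The compounds shown leave open whether phenyl in place of 4-methylbenzyl on an amide-type nitrogen changes the result in this assay at all.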